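The source may report more compounds than this note shows. Statements on the series, on what has been measured and on what is new or still open speak of the compounds shown alone.

Compound 2 `Cc1nn(C(=O)C2CC2)c(N)c1-c1ccc(Cl)c(Cl)c1` is the lower of the two numbers obtained so far in an assay on Sf9 cells for inhibition of mitogen-activated protein kinase kinase kinase 14 (Homo sapiens), read by ADP-Glo, with a stated time of 60 min (a higher number here means a weaker inhibitor, a lower number a stronger inhibitor), where compound 2 gives 24300 nM. Its nearest neighbour is compound 1 `CCC(=O)n1nc(C)c(-c2ccc(Cl)c(Cl)c2)c1N`, which in this assay gives 27400 nM; the step of a 1.1-fold lower number from compound 1 to compound 2 (0.05 log units; within the scatter) is the only measured one in this set, and it does not reach beyond the scatter, so compound 1 and compound 2 cannot be ordered on these data.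

Compound 3 `Cc1nn(C(=O)C2CCC2)c(N)c1-c1ccc(Cl)c(Cl)c1` has not been measured. It differs from compound 2 by cyclobutyl in place of cyclopropyl on a carbonyl carbon. For the measured compounds named here, the only step that bears on this change is the one from an ethyl group to the cyclopropyl ring, which was a 1.1-fold lower number from compound 1 to compound 2 (0.05 log units; within the scatter), and no step beyond the scatter has been seen at this position. Growing the ring by one carbon is therefore expected to leave the number close to that of compound 2, with the expected step of a 1.1-fold lower number from compound 2 to compound 3 (0.04 log units; within the scatter) not reliably beyond the scatter. In this assay compound 3 is accordingly expected to give about 22000 nM, estimated to fall between 9000 nM and 50000 nM.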

Compound 3, half-maximal inhibitory concentration: 2900 nM
For compound 3 the middle estimate is 7.6-fold (0.88 log units) above the measured one, and the stated range ends above it.
By their numbers in this assay, from the lowest: compound 3; then compounds 2 and 1 (each within the scatter of the next).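

In this assay, for the compounds shown here, this position on the carbonyl carbon turns out to respond to the group it carries: the step of an 8.4-fold lower number from compound 2 to compound 3 (0.92 log units; beyond the scatter) is the first here to go beyond the scatter, and it comes from cyclobutyl in place of cyclopropyl alone. The step of a 9.4-fold lower number from compound 1 to compound 3 (0.98 log units; beyond the scatter), with cyclobutyl in place of ethyl, is also beyond the scatter, whereas the ethyl and cyclopropyl compounds could not be ordered, so among these three groups only cyclobutyl stands apart. Nothing available explains why the four-membered ring differs from the three-membered one.

The compounds shown leave open whether the lower number continues with a larger ring such as cyclopentyl or cyclohexyl, or whether a branched chain such as isopropyl or tert-butyl on the same carbonyl carbon would do as well as a ring. They also leave open whether a cyclobutyl ring carrying a hydroxyl group or an amine would keep the step, and whether the step holds on any other core.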